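This account rests on a few compounds, and the source may have more. Where it says the series, first, only, none or still open, it means among the compounds named here.

In an ADME assay (liver) for metabolic stability, with Liver microsome (Homo sapiens) as the target, using microsomes and NADPH, with a stated time of 30 min, tested at 1 uM (a lower number here means slower removal, a higher number faster removal of the compound), compound 3 `Nc1ccc(S(=O)(=O)N2CCN(c3ncc(C(O)(C(F)(F)F)C(F)(F)F)cc3-c3cccnc3)CC2)cn1` gives 17 mL.min-1.g-1 and is the lowest of the three measured, with compound 2 `CS(=O)(=O)Nc1cccc(-c2cc(C(O)(C(F)(F)F)C(F)(F)F)cnc2N2CCN(S(=O)(=O)c3ccc(N)nc3)CC2)c1` at 40 mL.min-1.g-1 and compound 1 `CC(C)(C)n1cc(-c2cc(C(O)(C(F)(F)F)C(F)(F)F)cnc2N2CCN(S(=O)(=O)c3ccc(N)nc3)CC2)cn1` at 86 mL.min-1.g-1 on the same core. Next comes compound 4 `Nc1ccc(S(=O)(=O)N2CCN(c3ncc(C(O)(C(F)(F)F)C(F)(F)F)cc3-c3cncc(F)c3)CC2)cn1` with fluoro in place of hydrogen on an aromatic carbon as its change, pyridin-3-yl becoming 5-fluoropyridin-3-yl. The steps of a 5.1-fold lower number from compound 1 to compound 3 (0.70 log units; beyond the scatter) and a 2.4-fold lower number from compound 2 to compound 3 (0.37 log units; beyond the scatter) and a 2.2-fold lower number from compound 1 to compound 2 (0.33 log units; beyond the scatter) are modest and each replaces a whole group on this aromatic carbon. None is a fluoro-for-hydrogen change, so they give no direction and no step beyond the scatter is expected. The estimated step is a 1.2-fold higher number from compound 3 to compound 4 (0.07 log units; within the scatter) on this reading. For compound 4 the expected value is 20 mL.min-1.g-1 with an estimated range of 10 mL.min-1.g-1 to 38 mL.min-1.g-1 around it.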

Compound 4, intrinsic clearance in microsomes: 24 mL.min-1.g-1
Estimate against measurement, compound 4: 1.2-fold (0.08 log units) below, within the range that was stated.
By their numbers in this assay, from the lowest: compounds 3, 4 and 2 (each within the scatter of the next, the first and the last beyond it); then compound 1.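

In this assay, fluoro two atoms from the ring nitrogen leaves compound 4 indistinguishable from compound 3 (a 1.4-fold higher number from compound 3 to compound 4 (0.15 log units; within the scatter)), so this position tolerates the change within the scatter. Compound 4 also stays within the scatter of the 3-(methanesulfonamido)phenyl compound (a 1.7-fold lower number from compound 2 to compound 4 (0.22 log units; within the scatter)), while its gap to the 1-(tert-butyl)-1H-pyrazol-4-yl compound remains beyond it (a 3.6-fold lower number from compound 1 to compound 4 (0.55 log units; beyond the scatter)). No available evidence explains these results. Open, from the compounds shown here alone, is whether a nitrile, methoxy or amine at this place would shift the number beyond the scatter.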